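From Pyridin-4-yl to Pyridin-3-yl on a Carbonyl Carbon

A few compounds are considered here, and "the series" means these few. Any claim that something is new, unique, unknown or untested is made for them only; others in the source may bear on it.

Compound 1 `Cc1ccc(S(=O)(=O)NCc2ccc(CNC(=O)c3ccc([N+](=O)[O-])cc3)cc2)cc1` and compound 2 `Cc1ccc(S(=O)(=O)NCc2ccc(CNC(=O)c3ccncc3)cc2)cc1` share one core and differ only in the group on the carbonyl carbon. In an assay on MDA-MB-231 cells for binding affinity to C-X-C chemokine receptor type 4 (Homo sapiens), read by immunofluorescence and microscopy, with stated times of 10 min and 30 min (a higher number here means that more compound is needed for the effect, a lower number that less compound is needed), compound 1 gives 10 nM, and in this assay compound 2 gives 10 nM; the step of no change at the digits printed from compound 1 to compound 2 (within the scatter) was flat within the scatter, so compound 2 stands level with compound 1 at the digits shown. Compound 3 `Cc1ccc(S(=O)(=O)NCc2ccc(CNC(=O)c3cccnc3)cc2)cc1` has not been measured; it differs from compound 2 as follows: pyridin-3-yl in place of pyridin-4-yl on a carbonyl carbon. Among the compounds with values here, the single measured step bears on it only loosely, since it concerns a different pair of groups at the same carbonyl carbon, yet it showed no change. Nothing in these data points to a shift beyond the scatter, so compound 3 is expected to show a step of no change at the digits printed from compound 2 to compound 3 (within the scatter) in this assay. Compound 3 is accordingly estimated at 10 nM, within 4 nM to 30 nM.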

Compound 3, effective concentration (reported as EC, without a stated level of effect): > 1000 nM
Compound 3 ended at the assay's limit; the forecaster's own chance of this, stated with the estimate: 5%; middle value at least 100-fold (2.00 log units) away from the limit.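

In this assay, pyridin-3-yl in place of pyridin-4-yl on the carbonyl carbon, the same atoms joined differently, gives an at least 100-fold higher number from compound 2 to compound 3 (2.00 log units; beyond the scatter), so this position is not indifferent to how the group on it is joined. With 4-nitrophenyl as the starting group the change gives an at least 100-fold higher number from compound 1 to compound 3 (2.00 log units; beyond the scatter), whereas the earlier step gave no change at the digits printed from compound 1 to compound 2 (within the scatter), so that flat step did not mean that any aromatic ring is accepted here. Compound 3 reads > 1000 nM, which is a limit of the assay and not a number: the limit of > 1000 nM in this assay, at which 1 of the 3 values shown sits.

The compounds shown leave open how far beyond that limit compound 3 lies. They also leave open whether a phenyl group carrying an amine or a carboxylic acid, on the same carbonyl carbon, would stand with compound 2 or with compound 3.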